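The compounds below may be only part of what the source reports. "The series", "measured", "known", "first", "only" and "open" are said of these compounds alone.

In a functional assay on HL-60 cells (Homo sapiens) for cytotoxicity, read by MTT assay, with a stated time of 46 h (a lower number here means a stronger inhibitor, a higher number a weaker inhibitor), compound 2 `O=C1/C(=C\c2ccncc2)C(c2ccccc2)Oc2ccccc21` gives 1100 nM. This lies within the scatter of compound 1 `O=C1/C(=C/c2ccncc2)C(c2ccccc2)Oc2ccccc21`, which gives 900 nM, while compound 3 `O=C1/C(=C/c2ccccc2)C(c2ccccc2)Oc2ccc(O)cc21` gives a clearly higher 5800 nM. Compound 4 `Cc1ccc(/C=C2\C(=O)c3ccccc3OC2c2ccccc2)cc1` carries 4-methylphenyl in place of pyridin-4-yl on a double-bonded chain carbon bound to a double-bonded ring carbon. Among the compounds with values here, the only measured step, a 1.2-fold higher number from compound 1 to compound 2 (0.09 log units; within the scatter), concerns the double bond alone and says nothing direct about this exchange. Compound 3, at 5800 nM, also has a ring of carbon only at that place but differs elsewhere too, so it offers only a weak hint. A moderate rise is therefore expected, a 2.3-fold higher number from compound 2 to compound 4 (0.36 log units; beyond the scatter). For compound 4 the estimated value is 2500 nM, with an expected range from 800 nM to 8000 nM.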

Compound 4, half-maximal inhibitory concentration: 40800 nM
Beside the measured number, compound 4's estimate is 16-fold (1.21 log units) below it; the measured number lies above the stated range.
By their numbers in this assay, from the lowest: compounds 1 and 2 (each within the scatter of the next); then compound 3; then compound 4.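

The exchange of pyridin-4-yl for 4-methylphenyl on a double-bonded chain carbon bound to a double-bonded ring carbon gives a step of a 37-fold higher number from compound 2 to compound 4 (1.57 log units; beyond the scatter), so this place responds strongly to the group it carries, which the earlier double-bond step could not show. Nothing given here explains this step. The exchange removes the ring nitrogen and adds the methyl together, so the compounds shown leave open which of the two changes carries the step. An unsubstituted phenyl on the shared core, or a pyridin-3-yl at this place, would separate these readings.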